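The source may hold more compounds than are shown below. What is called first, only, known or untested is meant among the compounds shown, and "the series" means these compounds.

Measured so far in a functional assay on the whole organism for inhibition, with Mythimna separata as the target, with a stated time of 5 days; a higher number here means that more compound is needed for the effect, a lower number that less compound is needed:
- compound 1 `Cc1cc(C)cc(-c2nnc(COc3cnn(C(C)(C)C)c(=O)c3Cl)s2)c1`: > 299000 nM (a limit of the assay, not a number)
- compound 2 `CC(C)(C)n1ncc(OCc2nnc(-c3ccccc3)s2)c(Cl)c1=O`: 200000 nM

Compound 1 gives > 299000 nM in this assay, and this value is a limit of the assay rather than a number. Compound 2 gives 200000 nM in this assay. Compound 2 therefore holds the only number shown; the one other value is a limit. Going by the values given here, the single measured step, an at least 1.4-fold lower number from compound 1 to compound 2 (0.17 log units; that floor lies within the scatter), comes from exchanging 3,5-dimethylphenyl for phenyl on an aromatic carbon, and its floor lies within the scatter, with compound 1 sitting at the limit of > 299000 nM in this assay, at which 1 of the 2 values shown sits.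

Compound 3 `CC(C)(C)n1ncc(OCc2nnc(-c3ccccc3F)s2)c(Cl)c1=O` has not yet been measured. It differs from compound 2 by fluoro in place of hydrogen on an aromatic carbon. Among the compounds with values here, the one measured step concerns the same ring, and it showed no change beyond the scatter, so no step beyond the scatter is expected in this assay from compound 2 to compound 3. Compound 3 is estimated to give about 200000 nM, within 90000 nM to 450000 nM. The expected step is no change at the digits printed from compound 2 to compound 3 (within the scatter).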

Compound 3, half-maximal effective concentration: 121000 nM
The estimate for compound 3 lay 1.7-fold (0.22 log units) above the measured number; measured number inside the range.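

In this assay, putting fluoro on the aromatic ring, ortho to a large group, gives a 1.7-fold lower number from compound 2 to compound 3 (0.22 log units; within the scatter), so this single atom makes no change that can be told from the scatter. Set against the 3,5-dimethylphenyl of compound 1, however, the 2-fluorophenyl gives a step that does clear the scatter, the first one in this small set: an at least 2.4-fold lower number from compound 1 to compound 3 (0.39 log units; beyond the scatter). Compound 1 stands at a limit of the assay, not a number, so this step is only a floor: the limit of > 299000 nM in this assay, at which 1 of the 3 values shown sits.

The compounds shown leave open how a methoxy group, a nitrile or an amine would behave in the fluoro's place on this ring. They also leave open whether fluoro elsewhere on the ring would read any differently.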